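The compounds below may be only part of what the source reports. "The series", "measured", "known", "first", "only" and "open" are said of these compounds alone.

Compound 1 `CC(=O)OC[C@H]1O[C@@H](n2cc(CN3C(=O)/C(=C/c4ccccc4)c4ccccc43)nn2)[C@H](OC(C)=O)[C@@H](OC(C)=O)[C@@H]1OC(C)=O` gives 37100 nM in a functional assay on HeLa cells (Homo sapiens) for cytotoxicity, read by sulforhodamine B assay, with a stated time of 48 h; on this read-out lower numbers stand for stronger inhibition and higher numbers for weaker inhibition.
Compound 2 `CC(=O)OC[C@H]1O[C@@H](n2cc(CN3C(=O)/C(=C/C=C/c4ccccc4)c4ccccc43)nn2)[C@H](OC(C)=O)[C@@H](OC(C)=O)[C@@H]1OC(C)=O` gives only a limit of the assay, > 100000 nM, in this assay.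
Compound 3 `CC(=O)OC[C@H]1O[C@@H](n2cc(CN3C(=O)/C(=C/c4ccc(N(C)C)cc4)c4ccccc43)nn2)[C@H](OC(C)=O)[C@@H](OC(C)=O)[C@@H]1OC(C)=O` gives 26300 nM in this assay.

Compound 3 holds the lowest of the two numbers; compound 1 is nearest, with a 1.4-fold lower number from compound 1 to compound 3 (0.15 log units; within the scatter) lying within the scatter, while compound 2 sits at the limit (the limit of > 100000 nM in this assay, at which 1 of the 3 values shown sits). Compound 4 `CC(=O)OC[C@H]1O[C@@H](n2cc(CN3C(=O)/C(=C/c4ccc5ccccc5c4)c4ccccc43)nn2)[C@H](OC(C)=O)[C@@H](OC(C)=O)[C@@H]1OC(C)=O` differs from compound 3 by naphthalen-2-yl in place of 4-(dimethylamino)phenyl on a double-bonded chain carbon bound to a double-bonded ring carbon. Among the compounds with values here, two measured steps bear on this change: a 1.4-fold lower number from compound 1 to compound 3 (0.15 log units; within the scatter) was within the scatter, and an at least 3.8-fold lower number from compound 2 to compound 3 (0.58 log units; beyond the scatter) was at least modest. A plain phenyl and a dimethylaminophenyl thus gave similar numbers, and the step to compound 4 is expected to be small, a 1.3-fold higher number from compound 3 to compound 4 (0.12 log units; within the scatter), a slight rise toward compound 1. Compound 4 is estimated at 35000 nM, with a range from 15000 nM to 90000 nM.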

Compound 4, half-maximal inhibitory concentration: > 100000 nM
Compound 4 was reported as a limit; the forecaster's own chance of this, stated with the estimate: 15%; at least 2.8-fold (0.45 log units) between middle value and limit.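

Compound 4 gives only a limit in this assay, the second such result at this place: the limit of > 100000 nM in this assay, at which 2 of the 4 values shown sit.

With an at least 3.8-fold higher number from compound 3 to compound 4 (0.58 log units; beyond the scatter) and an at least 2.6-fold higher number from compound 1 to compound 4 (0.43 log units; beyond the scatter), the second carbon-only aromatic ring of naphthalen-2-yl brings a loss beyond the scatter, whereas the change between phenyl and 4-(dimethylamino)phenyl stayed within it. The step between compound 2 and compound 4 cannot be read, since both are limits.

Going by these compounds, the order of these two compounds therefore stays open. Also open, on these data alone, is whether a phenyl carrying a methoxy group or a carboxylic acid at this place would give a measurable number.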